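Dropping the Methoxy Group from Compound 3

The compounds below may be only part of what the source reports. "The series", "measured", "known", "first", "only" and "open" are said of these compounds alone.

Measured in a functional assay on A-375 cells (Homo sapiens) for antiproliferative activity, read by MTT assay, with a stated time of 24 h, tested at 11.11 ug/mL; a lower number here means a weaker effect, a higher number a stronger effect of the compound at the concentration tested:
Compound 1, `COc1ccc2nc(C(=O)Nc3ccc(-c4ccccc4)cc3)c(C)c(O)c2c1`, gives 36.2%.
Compound 2, `Cc1c(C(=O)Nc2ccc(-c3ccccc3)cc2)nc2ccccc2c1O`, gives 26.5%.
Compound 3, `COc1ccc2nc(C(=O)Nc3ccc(-c4ccccc4)cc3)c(C)c(C(=O)O)c2c1`, gives 47.9%.

Compound 3 stands highest of the three numbers. Its nearest neighbour is compound 1, separated by the step of a number 11.7 percentage points higher from compound 1 to compound 3 (beyond the scatter), which exchanged the hydroxy of compound 1 for the carboxy of compound 3 and lay beyond the scatter. Compound 2 lies furthest below compound 3.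

The next compound, compound 4, `Cc1c(C(=O)Nc2ccc(-c3ccccc3)cc2)nc2ccccc2c1C(=O)O`, differs from compound 3 in one place: hydrogen in place of methoxy on an aromatic carbon. The same exchange has been made once before within this set, on compound 1, where the step of a number 9.7 percentage points lower from compound 1 to compound 2 (within the scatter) stayed within the scatter. Within the data shown here, that single precedent is the only measured step that bears on the change, and it points to a small loss, or to no change beyond the scatter.

On that basis compound 4 is expected to fall a little below compound 3, by about a number 7.9 percentage points lower from compound 3 to compound 4 (within the scatter) in this assay. The estimate for compound 4 is 40%, with a likely range from 28% to 52%.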

Compound 4, a percentage reported as inhibition, at one concentration (the size of the read-out at that concentration, not a potency): 20.3%
Compound 4: middle estimate off by 19.7 percentage points, on the high side; measured number outside the range, below it.
By their numbers in this assay, from the lowest: compounds 4, 2 and 1 (each within the scatter of the next, the first and the last beyond it); then compound 3.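

In this assay, the methoxy group does not carry a fixed contribution: on the core bearing the carboxy group, hydrogen in place of methoxy gives a number 27.6 percentage points lower from compound 3 to compound 4 (beyond the scatter), and the same exchange on the core bearing the hydroxy group behaves differently: the same change on two cores in this assay, a number 9.7 percentage points lower (within the scatter) from compound 1 to compound 2 and a number 27.6 percentage points lower (beyond the scatter) from compound 3 to compound 4, 17.9 percentage points apart, beyond the scatter of two such steps The exchange of hydroxy for carboxy is equally dependent on its partner, since the gain seen with methoxy present does not carry over to the core without it, where the step is a number 6.2 percentage points lower from compound 2 to compound 4 (within the scatter): the same change on two cores in this assay, a number 11.7 percentage points higher (beyond the scatter) from compound 1 to compound 3 and a number 6.2 percentage points lower (within the scatter) from compound 2 to compound 4, 17.9 percentage points apart, beyond the scatter of two such steps The two changes therefore do not act independently in these four compounds, and only compound 3 combines the methoxy and carboxy groups, with its single-change steps to both compound 1 and compound 4 lying beyond the scatter.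

The compounds shown leave open whether the higher number needs methoxy itself, or whether an ethoxy group, a fluorine atom or an amine on the same aromatic carbon would serve alongside the carboxy group. They also leave open whether a methyl ester or a primary amide in place of the carboxy group would keep that number.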